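Swapping the Chain End in a Glutamate Receptor Modulator

The compounds below may be only part of what the source reports. "The series", "measured", "known", "first", "only" and "open" are said of these compounds alone.

Three compounds have been measured in an assay on HEK293 cells for positive allosteric modulation of metabotropic glutamate receptor 3 (Rattus norvegicus), read by thallium flux, with a stated time of 2.5 min; on this read-out lower numbers stand for smaller maximal responses and higher numbers for larger maximal responses:

Compound 1 `Cc1c(OCCCCOc2ccc(C(=O)O)c(Cl)c2)ccc(C(=O)CC(C)C)c1O`: 49.5%
Compound 2 `Cc1c(OCCCCOCOc2ccc(C(=O)O)cc2)ccc(C(=O)CC2CCCC2)c1O`: 46.9%
Compound 3 `Cc1c(OCCCCOc2ccc(C(=O)C(C)C)c(O)c2C)cccc1C(=O)O`: 27.1%

Compound 2 sits close to compound 1, within the usual scatter, and the pair lies well above compound 3. Compound 4 `Cc1c(OCCCCOc2ccc(C(=O)O)c(Cl)c2)ccc(C(=O)CC2CCCC2)c1O` is not yet measured. It differs from compound 2 in one place: 4-carboxy-3-chlorophenyl in place of (4-carboxyphenoxy)methyl on an oxygen on a saturated carbon. The group that enters is the same one carried by compound 1. Because compound 1 gives 49.5%, which is close to compound 2, no change beyond the scatter is expected in this assay for this swap. The expected step is a number 1.1 percentage points higher from compound 2 to compound 4 (within the scatter), within the scatter. Compound 4 is therefore estimated at 48%, with a range from 36% to 60%.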

Compound 4, largest response reached (reported as percent of maximum), in percent of the reference or control that the assay uses: 40%
For compound 4 the middle estimate is 8 percentage points above the measured one; measured number inside the range.
By their numbers in this assay, from the lowest: compound 3; then compounds 4, 2 and 1 (each within the scatter of the next).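

For the compounds shown here, putting 4-carboxy-3-chlorophenyl in place of (4-carboxyphenoxy)methyl on an oxygen on a saturated carbon gives a number 6.9 percentage points lower from compound 2 to compound 4 (within the scatter) in this assay, the first direct reading of this swap. Cyclopentyl in place of isopropyl on a saturated chain carbon bound to a carbonyl carbon gives a number 9.5 percentage points lower from compound 1 to compound 4 (within the scatter), so neither single change moves the response beyond the scatter. No measured evidence explains either step. Still open, from the compounds shown here alone, is how a fluorine in place of the chlorine, or a cyclohexyl in place of the cyclopentyl, would read in this assay.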